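The source may report more compounds than this note shows. Statements on the series, on what has been measured and on what is new or still open speak of the compounds shown alone.

Measured compounds in the study:
compound 1, `Nc1scc(CN2CCN(c3ccc(Cl)cc3Cl)CC2)c1C(=O)c1ccc(Cl)cc1` — -11%
compound 2, `Nc1scc(CN2CCN(c3ccc(OC(F)(F)F)cc3)CC2)c1C(=O)c1ccc(Cl)cc1` — -13%
compound 3, `Nc1scc(CN2CCN(c3cccnc3)CC2)c1C(=O)c1ccc(Cl)cc1` — 3.4%

All three share one core and were tested in a functional assay on CHO cells with adenosine receptor A1 (Homo sapiens) as the target, read by cAMP accumulation and immunoassay, with a stated time of 6 min, tested at 0.1 uM; on this read-out higher numbers stand for a weaker effect at the one concentration tested and lower numbers for a stronger effect. Compound 3 stands highest of the three numbers, and both of its neighbours lie beyond the scatter from it: the change from compound 1 gives a number 14.4 percentage points higher from compound 1 to compound 3 (beyond the scatter), and the change from compound 2 gives a number 16.4 percentage points higher from compound 2 to compound 3 (beyond the scatter). Compounds 1 and 2 themselves sit within the scatter of each other, as a number 2 percentage points lower from compound 1 to compound 2 (within the scatter) shows.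

Compound 4, `Nc1scc(CN2CCN(c3c(F)cccc3F)CC2)c1C(=O)c1ccc(Cl)cc1`, has not yet been tested in this assay. It differs from compound 3 in one place: 2,6-difluorophenyl in place of pyridin-3-yl on an amine nitrogen in a ring. The two measured steps that bear on this change are the ones that introduced pyridin-3-yl, each of which raised the number by a modest amount beyond the scatter. Compound 4 carries a carbon-only aromatic ring on the same ring nitrogen, as compounds 1 and 2 do, so the expected step is a modest one downward, back toward the values of those two compounds. The account therefore estimates that compound 4 shows a step of a number 11.4 percentage points lower from compound 3 to compound 4 (beyond the scatter), giving an expected value of -8% in this assay, within a range from -25% to 8%.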

Compound 4, a percentage reported as activity, at one concentration (the size of the read-out at that concentration, not a potency): -23%
Estimate against measurement, compound 4: 15 percentage points above, within the range that was stated.
By their numbers in this assay, from the lowest: compounds 4, 2 and 1 (each within the scatter of the next, the first and the last beyond it); then compound 3.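

In this assay the step of a number 26.4 percentage points lower from compound 3 to compound 4 (beyond the scatter) shows that a carbon-only aromatic ring on this amine nitrogen gives a lower number than pyridin-3-yl even when it carries only fluorine, with neither the chlorine of compound 1 nor the trifluoromethoxy of compound 2, and no compound shown goes against this. The new compound also separates the two earlier aryl groups to different degrees: the change a number 10 percentage points lower from compound 2 to compound 4 (within the scatter) leaves 2,6-difluorophenyl unresolved from 4-(trifluoromethoxy)phenyl, while the change a number 12 percentage points lower from compound 1 to compound 4 (beyond the scatter) sets it apart from 2,4-dichlorophenyl. Nothing given here explains why these replacements shift the read-out.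

The compounds shown leave open whether an amine or a methoxy group on the carbon-only ring, or a single fluorine in place of two, would keep the number near that of compound 4 or move it toward that of compound 3. They also leave open how these groups would behave with anything other than the 4-chlorobenzoyl group that all four compounds share, and at any other concentration.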